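Pyrrolidin-1-yl in place of chloro: working notes

The source may report more compounds than this note shows. Statements on the series, on what has been measured and on what is new or still open speak of the compounds shown alone.

Measured so far in a functional assay on SW480 cells (Homo sapiens) for antiproliferative activity, read by MTT assay, with a stated time of 48 h; a higher number here means a weaker inhibitor, a lower number a stronger inhibitor; values below.
- compound 1 (`COC/C1=C/C[C@](C)(CCC=C(C)C)/C=C/[C@@H](OC(=O)C=C(C)C)[C@](C)(OC)/C=C/C1=O`) gives 14600 nM
- compound 2 (`CC(C)=CCC[C@]1(C)/C=C/[C@@H](OC(=O)C=C(C)C)[C@](C)(O)/C=C/C(=O)/C(CCl)=C\C1`) gives 390 nM

Of these two, compound 2 (390 nM) holds the lower number and so is the stronger inhibitor in this assay, with a gap to compound 1 (14600 nM) beyond the scatter. These two compounds differ in more than one place, so their gap cannot be read as the result of a single change.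

The next compound is compound 3 (`CC(C)=CCC[C@]1(C)/C=C/[C@@H](OC(=O)C=C(C)C)[C@](C)(O)/C=C/C(=O)/C(CN2CCCC2)=C\C1`), which carries pyrrolidin-1-yl in place of chloro on a saturated chain carbon bound to a double-bonded ring carbon. Among the compounds with values here, no measured pair isolates this change. Within the data shown here, the only hint is that compound 1 (14600 nM) also lacks the chloro and has the higher number. A moderate loss of inhibition is therefore expected, with the estimated change being a 3.8-fold higher number from compound 2 to compound 3 (0.59 log units; beyond the scatter) in this assay, just beyond the scatter and uncertain in size. For compound 3 the estimated value is 1500 nM, with an expected range from 300 nM to 8000 nM.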

Compound 3, half-maximal inhibitory concentration: 310 nM
For compound 3 the middle estimate is 4.8-fold (0.68 log units) above the measured one; the range from low to high includes it.
By their numbers in this assay, from the lowest: compounds 3 and 2 (each within the scatter of the next); then compound 1.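

Pyrrolidin-1-yl in place of chloro on a saturated chain carbon bound to a double-bonded ring carbon is the first single change that can be read in this series, and in this assay it gives no separation (a 1.3-fold lower number from compound 2 to compound 3 (0.10 log units; within the scatter)). At this position the chloro is therefore not required to keep the number of compound 2 in this assay, and a much larger group carrying a ring and a nitrogen is accepted in its place; compound 1 differs from both in more than one place, so its gap says nothing about this change taken alone. Nothing available accounts for the match between the two groups.

Still open, from the compounds shown here alone, is whether another amine, such as morpholin-4-yl or diethylamino, or a plain hydroxyl on the same chain carbon would stay level with this pair or fall closer to compound 1 at 14600 nM. Going by these compounds, it also remains unknown how much of the number of compound 1 belongs to its methoxy on the chain and how much to its second methoxy on the core.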